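Triazole in Place of the Lactam Ring: Compound 4

A few compounds are considered here, and "the series" means these few. Any claim that something is new, unique, unknown or untested is made for them only; others in the source may bear on it.

Compound 1 `CC(C)C(Cc1ncc[nH]1)c1ccc(-c2ccc3cccc(F)c3c2)[nH]c1=O`: 11 nM
Compound 2 `CC(C)C(Cc1nnn[nH]1)c1ccc(-c2ccc3cccc(F)c3c2)[nH]c1=O`: 34 nM
Compound 3 `CC(C)C(/C=C1/CCNC1=O)c1ccc(-c2ccc3cccc(F)c3c2)[nH]c1=O`: 5.3 nM

All three compounds share one core and differ only in the group on a saturated chain carbon bound to an aromatic carbon and a saturated chain carbon. In an assay on CHO cells for displacement of a labelled ligand from prostaglandin E2 receptor EP3 subtype (Homo sapiens), read by radioligand binding (on this read-out higher numbers stand for weaker inhibition and lower numbers for stronger inhibition), compound 3 gives 5.3 nM, the lowest number of the three: the step of a 2.1-fold lower number from compound 1 to compound 3 (0.32 log units; beyond the scatter) and the step of a 6.4-fold lower number from compound 2 to compound 3 (0.81 log units; beyond the scatter) both lie beyond the scatter, so compound 3 is the strongest inhibitor here.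

Compound 4 `CC(C)C(Cc1nnc[nH]1)c1ccc(-c2ccc3cccc(F)c3c2)[nH]c1=O` is not yet measured. It differs from compound 3 in one place: a group of 6 heavy atoms (3 carbon, 3 nitrogen; one five-membered aromatic ring with 3 hetero atoms) in place of a group of 7 heavy atoms (5 carbon, 1 nitrogen, 1 oxygen; one five-membered non-aromatic ring with 1 hetero atom), on a saturated chain carbon bound to an aromatic carbon and a saturated chain carbon

Going by the values given here, two measured steps bear on this change, since compound 1 and compound 2 each carry a five-membered aromatic ring with nitrogen on the same carbon. Going the other way, a 2.1-fold lower number from compound 1 to compound 3 (0.32 log units; beyond the scatter) and a 6.4-fold lower number from compound 2 to compound 3 (0.81 log units; beyond the scatter) show that swapping the aromatic ring for the non-aromatic ring lowered the number, modestly in both cases. The ring entering in compound 4 carries three hetero atoms, more than in compound 1 and fewer than in compound 2, and a 3.1-fold higher number from compound 1 to compound 2 (0.49 log units; beyond the scatter) showed a higher number as hetero atoms increased. A step upward is therefore expected, a 3.4-fold higher number from compound 3 to compound 4 (0.53 log units; beyond the scatter), of a modest size. For compound 4 the expected value in this assay is 18 nM, with a range from 8 nM to 45 nM.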

Compound 4, inhibition constant: 10 nM
Estimate against measurement, compound 4: 1.8-fold (0.26 log units) above, within the range that was stated.
By their numbers in this assay, from the lowest: compounds 3, 4 and 1 (each within the scatter of the next, the first and the last beyond it); then compound 2.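

In this assay, the (4H-1,2,4-triazol-3-yl)methyl group of compound 4 holds up as well as the non-aromatic ring group it replaces: a 1.9-fold higher number from compound 3 to compound 4 (0.28 log units; within the scatter) lies within the scatter, so at this place an aromatic ring with three hetero atoms can stand in for that ring with no readable loss. Among the aromatic rings, a 1.1-fold lower number from compound 1 to compound 4 (0.04 log units; within the scatter) also lies within the scatter, while a 3.4-fold lower number from compound 2 to compound 4 (0.53 log units; beyond the scatter) lies beyond it, which sets the 1H-tetrazol-5-yl group of compound 2 apart from the 4H-1,2,4-triazol-3-yl group. The earlier step from the imidazole to the tetrazole might have suggested a steady rise in the number with each added ring nitrogen, but compound 4 goes against that reading, as the change shows only when the tetrazole is reached.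

Nothing measured here explains what sets compound 2 apart from compound 4. Also open, going by these compounds, is how an amine or a carboxylic acid would read in place of the ring, and whether a longer chain leading to the triazole would keep the number of compound 4.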